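The source may report more compounds than this note shows. Statements on the series, on what has been measured and on what is new or still open speak of the compounds shown alone.

Measured so far:
compound 1 `CC1CCN(c2ccc(Nc3ncc4c(n3)N(C3CCCC3)CC(=O)N4)cc2)CC1` — > 30000 nM
compound 2 `CN1CCN(c2ccc(Nc3ncc4c(n3)N(C3CCCC3)CC(=O)N4)nc2)CC1` — > 30000 nM

In a functional assay on HeLa cells (Homo sapiens) for inhibition, read by MTT assay, with a stated time of 48 h (a lower number here means a stronger inhibitor, a higher number a weaker inhibitor), compound 1 gives > 30000 nM, which is a limit of the assay rather than a number. Compound 2 gives > 30000 nM, again a limit. Compound 2 therefore stands at the limit of > 30000 nM in this assay, at which 2 of the 2 values shown sit. Compound 3 `CC1CCN(c2ccc(Nc3ncc4c(n3)N(C3CCCC3)CC(=O)N4)nc2)CC1` differs from compound 2 by 4-methylpiperidin-1-yl in place of 4-methylpiperazin-1-yl on an aromatic carbon. Going by the values given here, no measured step joins the two; with both measured values at the limit, no movement beyond the scatter is expected in this assay. The estimate for compound 3 is 40000 nM, ranging from 15000 nM to 120000 nM. The step that the limit leaves unreadable from compound 2 to compound 3 is expected to be none beyond the scatter.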

Compound 3, half-maximal inhibitory concentration: > 30000 nM
Compound 3: only a limit was reported (the forecaster's own chance of this, stated with the estimate: 85%); the middle value is on the limit's open side.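

In this assay compound 3 gives > 30000 nM, which is a limit of the assay; with compound 2 also at a limit, no step can be read between compound 2 and compound 3. The compounds shown leave open whether 4-methylpiperidin-1-yl and 4-methylpiperazin-1-yl differ at all in this assay.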